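From Hydroxy to Methyl at an Assay Limit

The compounds below may be only part of what the source reports. "The series", "measured", "known", "first", "only" and "open" are said of these compounds alone.

- Compound 1 `Fc1cccc(-c2nc(Nc3cccc(Br)c3)c3cc(F)ccc3n2)c1` gives > 50000 nM in a functional assay on MCF7 cells (Homo sapiens) for cytotoxicity, read by MTT assay, with a stated time of 48 h (on this read-out lower numbers stand for stronger inhibition and higher numbers for weaker inhibition), as a limit
- Compound 2 `Oc1ccc(Nc2nc(-c3cccc(F)c3)nc3ccc(F)cc23)cc1` gives > 50000 nM in this assay as a limit

Going by the values given here, compound 2 has no exact number and sits at the limit of > 50000 nM in this assay, at which 2 of the 2 values shown sit, among the compounds measured so far. Compound 3 `Cc1ccc(Nc2nc(-c3cccc(F)c3)nc3ccc(F)cc23)cc1` has methyl in place of hydroxy on an aromatic carbon, para to a large group, counted as methyl in place of hydroxy on an aromatic carbon in full. Among the compounds with values here, the one measured step that bears on this, a step that the two limits leave unreadable from compound 1 to compound 2, has no readable size, so it points in no direction. The estimated change is a number no higher from compound 2 to compound 3 (the limit leaves the size open) with no direction expected in this assay beyond the scatter. For compound 3 the estimate is 50000 nM, with an expected range of 20000 nM to 100000 nM and a good chance of another limit.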

Compound 3, half-maximal inhibitory concentration: > 50000 nM
Compound 3: only a limit was reported; the forecaster's own chance of this, stated with the estimate: 80%; the middle value lies on the limit itself.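

No step can be read among compound 1, compound 2 and compound 3, since each result is only a limit: the limit of > 50000 nM in this assay, at which 3 of the 3 values shown sit.

The compounds shown leave open how strongly each acts in this assay, and whether swapping hydroxy for methyl changes anything there.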